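Swapping a Cyclohexyl Ring for an Oxane Ring

The compounds below may be only part of what the source reports. "The series", "measured", "known", "first", "only" and "open" are said of these compounds alone.

Three measured compounds share one core and differ only in the group attached through a short saturated chain to the sulfonyl sulfur. Compound 1 `CCCCCCCCCCS(=O)(=O)/C=C/c1ccc(O)c(O)c1` carries a long straight chain; in a functional assay, read by fluorescence and spectrophotometry, with a stated time of 1 h (a higher number here means that more compound is needed for the effect, a lower number that less compound is needed), compound 1 gives 6800 nM. Compound 2 `O=S(=O)(/C=C/c1ccc(O)c(O)c1)CC1CCCCC1` carries a cyclohexyl on a saturated chain carbon bound to a sulfonyl sulfur, and in this assay compound 2 gives 7500 nM. Compound 3 `O=S(=O)(/C=C/c1ccc(O)c(O)c1)CCCC1CCCCC1` carries the cyclohexyl three bonds along the chain from a sulfonyl sulfur, and in this assay compound 3 gives 7900 nM. Within the data shown here, compound 2 stands second highest of the three numbers, but all three lie within the scatter of one another, and the one step between compounds that differ in one place, a 1.2-fold higher number from compound 1 to compound 3 (0.07 log units; within the scatter), is equally flat.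

Compound 4 `O=S(=O)(/C=C/c1ccc(O)c(O)c1)CC1CCCCO1` has not been measured. It differs from compound 2 by oxan-2-yl in place of cyclohexyl on a saturated chain carbon bound to a sulfonyl sulfur. Among the measured compounds shown here, no measured step exchanges a ring carbon for a ring oxygen; the only step that touches a ring, a 1.2-fold higher number from compound 1 to compound 3 (0.07 log units; within the scatter), concerns cyclohexyl against heptyl and stayed within the scatter. The expectation is therefore a step of a 1.2-fold higher number from compound 2 to compound 4 (0.08 log units; within the scatter), with no direction beyond the scatter. Compound 4 is estimated to give 9000 nM in this assay, within a range from 4000 nM to 20000 nM.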

Compound 4, half-maximal effective concentration: 10800 nM
For compound 4 the middle estimate is 1.2-fold (0.08 log units) below the measured one; low and high end bracket the measured number.
By their numbers in this assay, from the lowest: compounds 1, 2, 3 and 4 (each within the scatter of the next).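

In this assay, replacing cyclohexyl with oxan-2-yl on a saturated chain carbon bound to a sulfonyl sulfur gives a 1.4-fold higher number from compound 2 to compound 4 (0.16 log units; within the scatter), so a ring oxygen, which adds one hydrogen-bond acceptor, is accepted here without a step beyond the scatter. Unlike the earlier step, which set a ring against a straight chain, this one keeps a six-membered ring and its six heavy atoms and exchanges only one ring carbon for oxygen. No evidence is available on what lies behind this result.

The compounds shown leave open whether an amine or a carboxylic acid in place of the oxan-2-yl would also stay within the scatter. With each of the four numbers within the scatter of the next, they also do not show any change at this place that moves the number beyond the scatter.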